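This account rests on a few compounds, and the source may have more. Where it says the series, first, only, none or still open, it means among the compounds named here.

Measured in a functional assay on CCRF-CEM cells (Homo sapiens) for antiproliferative activity, read by trypan blue exclusion, with a stated time of 72 h; a higher number here means a weaker inhibitor, a lower number a stronger inhibitor:
compound 1 `CC(Br)C(=O)Nc1ccc(F)c(C(=O)NC(N)=O)c1`: 520 nM
compound 2 `NC(=O)NC(=O)c1cc(NC(=O)CCl)ccc1F`: 7680 nM
compound 3 `NC(=O)NC(=O)c1cc(NC(=O)CCl)ccc1Cl`: 2440 nM

Compound 2, at 7680 nM, has the highest number of the three and is the weakest inhibitor among them. Compound 3 lies nearest to it and compound 1 furthest. Compound 4 `NC(=O)NC(=O)c1cc(NC(=O)CI)ccc1F` has not yet been measured in this assay. It keeps the core of compound 2 and differs at one place: iodo in place of chloro on a saturated chain carbon bound to a carbonyl carbon. In words, this is iodo in place of chloro on a saturated chain carbon bound to a carbonyl carbon.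

Among the measured compounds shown here, no measured pair makes this exact change. The closest evidence is the large step of a 15-fold higher number from compound 1 to compound 2 (1.17 log units; beyond the scatter), with chloromethyl in place of 1-bromoethyl on a carbonyl carbon. That step alters both halogen and chain, so only part of it can be expected to carry over. The modest step of a 3.1-fold lower number from compound 2 to compound 3 (0.50 log units; beyond the scatter) concerns an aromatic carbon and bears only indirectly. A modest to large move towards a lower number is therefore expected. The expected change is a 5.1-fold lower number from compound 2 to compound 4 (0.71 log units; beyond the scatter). Compound 4 is estimated at 1500 nM, with an expected range of 400 nM to 5000 nM.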

Compound 4, half-maximal inhibitory concentration: < 10 nM
Compound 4: only a limit was reported (the forecaster's own chance of this, stated with the estimate: 2%); middle value at least 150-fold (2.17 log units) from the limit.
By their numbers in this assay, from the lowest: compound 1; then compound 3; then compound 2. At a limit, below all of these: compound 4.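

In this assay compound 4 gives no number, only a limit of the assay: the limit of < 10 nM in this assay, at which 1 of the 4 values shown sits.

Exchanging the halogen alone, on a saturated chain carbon bound to a carbonyl carbon, gives an at least 760-fold lower number from compound 2 to compound 4 (2.88 log units; beyond the scatter), far larger than the only other single-halogen exchange shown, on an aromatic carbon, which gives a 3.1-fold lower number from compound 2 to compound 3 (0.50 log units; beyond the scatter). Iodomethyl also goes past the 1-bromoethyl group, with an at least 52-fold lower number from compound 1 to compound 4 (1.71 log units; beyond the scatter), so the earlier lead of compound 1 over the chloromethyl compounds does not mark the low end of this position.

On these data alone, it remains open where bromomethyl, which would separate the halogen from the chain, falls on this scale, and what a plain methyl group or a 1-iodoethyl group would give. As far as these compounds go, it is also open whether iodomethyl holds this standing with chloro in place of fluoro on the aromatic carbon.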